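The source may report more compounds than this note shows. Statements on the series, on what has been measured and on what is new or still open speak of the compounds shown alone.

Working notes on the amide series. Compound 1 `O=C(CCC(=O)OCCCCCCSc1ccc([N+](=O)[O-])c2nonc12)Nc1ccccc1Cl` gives 330 nM in an assay on isolated protein for inhibition of glutathione S-transferase Mu 2 (Homo sapiens), with a stated time of 10 min; on this read-out higher numbers stand for weaker inhibition and lower numbers for stronger inhibition; compound 2 `Cc1ccccc1NC(=O)CCC(=O)OCCCCCCSc1ccc([N+](=O)[O-])c2nonc12` gives 440 nM; compound 3 `O=C(CCC(=O)OCCCCCCSc1ccc([N+](=O)[O-])c2nonc12)Nc1ccc(C(F)(F)F)cc1` gives 90 nM, the lowest number of the three, reached by a 3.7-fold lower number from compound 1 to compound 3 (0.56 log units; beyond the scatter) and a 4.9-fold lower number from compound 2 to compound 3 (0.69 log units; beyond the scatter). Compound 4 `O=C(CCC(=O)OCCCCCCSc1ccc([N+](=O)[O-])c2nonc12)Nc1ccc(F)c(Cl)c1` carries 3-chloro-4-fluorophenyl in place of 4-(trifluoromethyl)phenyl on an amide-type nitrogen. The two measured steps bear on this only in part: each replaced 2-chlorophenyl or 2-methylphenyl with 4-(trifluoromethyl)phenyl, whereas 3-chloro-4-fluorophenyl has not been tested on this nitrogen. Because a 3.7-fold lower number from compound 1 to compound 3 (0.56 log units; beyond the scatter) and a 4.9-fold lower number from compound 2 to compound 3 (0.69 log units; beyond the scatter) were modest, a modest move back toward the numbers of compound 1 and compound 2 in this assay is expected, as a 2.0-fold higher number from compound 3 to compound 4 (0.30 log units; within the scatter). Compound 4 is therefore estimated at 180 nM, with a range from 70 nM to 450 nM.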

Compound 4, half-maximal inhibitory concentration: 470 nM
The estimate for compound 4 lay 2.6-fold (0.42 log units) below the measured number; measured number outside the range, above it.
By their numbers in this assay, from the lowest: compound 3; then compounds 1, 2 and 4 (each within the scatter of the next).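

In this assay the step is a 5.2-fold higher number from compound 3 to compound 4 (0.72 log units; beyond the scatter): 3-chloro-4-fluorophenyl on this amide-type nitrogen does not keep the number given by 4-(trifluoromethyl)phenyl. With a 1.1-fold higher number from compound 2 to compound 4 (0.03 log units; within the scatter) and a 1.4-fold higher number from compound 1 to compound 4 (0.15 log units; within the scatter) both within the scatter, compound 3 alone stands apart from the other three amides. No measurement at hand accounts for this gap.

Open, from the compounds shown here alone, is whether the trifluoromethyl group itself carries the lower number of compound 3. Also open, going by these compounds, is how a phenyl ring bearing a nitrile, a carboxylic acid or an amine would read on this nitrogen.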